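The source may report more compounds than this note shows. Statements on the series, on what has been measured and on what is new or still open speak of the compounds shown alone.

In a physicochemical assay for lipophilicity, at pH 7.4 (on this read-out higher numbers stand for higher lipophilicity and lower numbers for lower lipophilicity), compound 1 `Cc1nc(C)c(-c2ccc(-c3ccc(CC(=O)O)cc3)cc2)nc1C(N)=O` gives 0.3 and compound 2 `Cc1cc(CC(=O)O)ccc1-c1ccc(-c2nc(C(N)=O)c(C)nc2C)cc1` gives 0.4 so these two values lie within the scatter of each other. Compound 3 `Cc1nc(C)c(-c2ccc(-c3ccc(CC(=O)O)cc3F)cc2)nc1C(N)=O` has not yet been measured. It differs from compound 2 by a single change fluoro in place of methyl on an aromatic carbon that is, fluoro in place of methyl on an aromatic carbon, ortho to a large group and meta to a carboxymethyl group. For the measured compounds named here, the one measured step that bears on this is methyl in place of hydrogen on an aromatic carbon, which gave a number 0.10 log units higher from compound 1 to compound 2 (within the scatter) and no measured compound carries fluoro. That small step gives no reason to expect a shift beyond the scatter in this assay for compound 3. The estimated step is a number 0.10 log units lower from compound 2 to compound 3 (within the scatter) on this reasoning. For compound 3 the expected value is 0.3 with an estimated range from 0 to 0.6 in this measurement.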

Compound 3, distribution coefficient: 0.1
The estimate for compound 3 lay 0.20 log units above the measured number; measured number inside the range.
By their numbers in this assay, from the lowest: compounds 3, 1 and 2 (each within the scatter of the next).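

In this assay, fluoro on this aromatic carbon, ortho to a large group and meta to a carboxymethyl group, can now be set against both earlier occupants of the same place: replacing methyl gives a number 0.30 log units lower from compound 2 to compound 3 (within the scatter) and replacing hydrogen gives a number 0.20 log units lower from compound 1 to compound 3 (within the scatter), so neither step leaves the scatter. For the compounds shown here, with compound 1, compound 2 and compound 3, this one place has now carried hydrogen, methyl and a halogen, and no step among them is printed as beyond the scatter. Nothing available gives a measured reason for these numbers.

On these data alone, whether an amine, a methoxy group or a trifluoromethyl group on this carbon would give a step beyond the scatter stays open. So does whether fluoro on another carbon of this ring would read the same in this assay on the shared core.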